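A Second Fluorine on the Far Ring of a Tolan

This account rests on a few compounds, and the source may have more. Where it says the series, first, only, none or still open, it means among the compounds named here.

The measured compounds:
compound 1, `CN(C)c1ccc(C#Cc2ccccc2)cc1`, > 3000 nM
compound 2, `CN(C)c1ccc(C#Cc2cccc(F)c2)cc1`, > 3000 nM
compound 3, `CN(C)c1ccc(C#Cc2cccc(F)c2F)cc1`, 119 nM

In a functional assay on LS174T cells (Homo sapiens) for antiproliferative activity, with a stated time of 4 days (on this read-out higher numbers stand for weaker inhibition and lower numbers for stronger inhibition), compound 1 reaches only a limit of the assay, > 3000 nM. Compound 2 likewise reaches only a limit, > 3000 nM. Compound 3 gives a number, 119 nM. Compound 2 therefore stands at the limit of > 3000 nM in this assay, at which 2 of the 3 values shown sit, together with compound 1, and neither of the two can be placed against the other.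

Two steps are known. The first, a step that the two limits leave unreadable from compound 1 to compound 2, is unreadable because both ends sit at the limit. Among the measured compounds shown here, the second, an at least 25-fold lower number from compound 2 to compound 3 (1.40 log units; beyond the scatter), is large and beyond the scatter, and it is the only readable guide here.

Compound 4, `CN(C)c1ccc(C#Cc2ccc(F)c(F)c2)cc1`, differs from compound 2 by fluoro in place of hydrogen on an aromatic carbon. For the measured compounds named here, the fluoro that enters compound 3 sits at a different place on the same ring than the one that enters compound 4, so the step to compound 3 bears on this change only loosely. A lower number than the limit of compound 2 is possible but far from certain. The account therefore expects compound 4 at 1200 nM, with a range from 150 nM to 6000 nM. This expectation means a step of an at least 2.5-fold lower number from compound 2 to compound 4 (0.39 log units; beyond the scatter).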

Compound 4, half-maximal inhibitory concentration: > 3000 nM
Compound 4: no number, only a limit; the forecaster's own chance of this, stated with the estimate: 45%; middle value at least 2.5-fold (0.39 log units) from the limit.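

Among the compounds shown here, compound 4, like compound 2, gives only a limit and no number, so no step between the two can be read, and the sentence stops at where they stand: the limit of > 3000 nM in this assay, at which 3 of the 4 values shown sit. The compounds shown leave open how far compounds 1, 2 and 4 lie from one another in this assay beyond that limit.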